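Three hydroxyphenyl groups on a shared core: one hydroxyl shifted

The source may hold more compounds than are shown below. What is called first, only, known or untested is meant among the compounds shown, and "the series" means these compounds.

Compound 1 `Oc1ccc(-c2cc(-c3ccc(O)cc3)nc(-c3ccc(O)cc3)c2)cc1` carries three 4-hydroxyphenyl groups on the shared core. In a functional assay on DU-145 cells (Homo sapiens) for cytotoxicity, read by CCK-8 assay, with a stated time of 4 days (on this read-out higher numbers stand for weaker inhibition and lower numbers for stronger inhibition), compound 1 gives 3160 nM. Compound 2 `Oc1cccc(-c2cc(-c3ccccc3O)nc(-c3ccccc3O)c2)c1` gives 5400 nM and compound 3 `Oc1ccccc1-c1cc(-c2ccccc2O)nc(-c2ccccc2O)c1` gives 5040 nM; both of these numbers lie within the usual scatter of the number for compound 1, so the three measured compounds cannot be told apart on this read-out.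

Compound 4 `Oc1ccc(-c2cc(-c3cccc(O)c3)cc(-c3ccc(O)cc3)n2)cc1` has not yet been measured. It differs from compound 1 in one place: 3-hydroxyphenyl in place of 4-hydroxyphenyl on an aromatic carbon. For the measured compounds named here, the only measured step that bears on this is the change at the same position of the core, from 3-hydroxyphenyl to 2-hydroxyphenyl, which gave a 1.1-fold lower number from compound 2 to compound 3 (0.03 log units; within the scatter). That step moved the hydroxyl on the aryl group opposite the ring nitrogen without any shift beyond the scatter, while the other two aryl groups stayed the same, as they do here.

On that basis, compound 4 is expected to give a number close to that of compound 1, with the step of a 1.1-fold higher number from compound 1 to compound 4 (0.04 log units; within the scatter) expected to stay within the scatter. The estimate for compound 4 is 3500 nM, with a range from 1600 nM to 7500 nM.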

Compound 4, half-maximal inhibitory concentration: 1400 nM
For compound 4 the middle estimate is 2.5-fold (0.40 log units) above the measured one; measured number below the stated range.
By their numbers in this assay, from the lowest: compound 4; then compounds 1, 3 and 2 (each within the scatter of the next).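

The aryl group opposite the ring nitrogen is not indifferent to where its hydroxyl sits: in this assay, with two 4-hydroxyphenyl groups kept in place, 3-hydroxyphenyl in place of 4-hydroxyphenyl gives a 2.3-fold lower number from compound 1 to compound 4 (0.35 log units; beyond the scatter). The earlier change at this position, 2-hydroxyphenyl in place of 3-hydroxyphenyl with two 2-hydroxyphenyl groups kept in place, gave only a 1.1-fold lower number from compound 2 to compound 3 (0.03 log units; within the scatter), so a flat response at this position cannot be assumed from one pair, though the step here is modest and rests on a single pair. Nothing among the data shown accounts for the step.

Going by these compounds, whether 2-hydroxyphenyl at this position would behave like 3-hydroxyphenyl when the other two groups are 4-hydroxyphenyl remains open, as does whether the same shift of the hydroxyl on either of those other two groups would move the number at all. Also open, on these data alone, is whether the hydroxyl itself matters at this position, which a plain phenyl, a methoxy group, an amine or a carboxylic acid in its place would test.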